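Amino for Chloro on a Shared Fused Core

The source may hold more compounds than are shown below. What is called first, only, known or untested is meant among the compounds shown, and "the series" means these compounds.

Three measured compounds share one core and differ only in where a chloromethyl group sits on the benzyl ring. Compound 1 `ClCc1ccccc1Cn1cnc2c(Cl)nc(Cl)nc21` was tested in a functional assay on DU-145 cells (Homo sapiens) for cytotoxicity, read by sulforhodamine B assay, with a stated time of 48 h (a higher number here means a weaker inhibitor of growth, a lower number a stronger inhibitor of growth), where compound 1 gives 2950 nM. Compound 2 `ClCc1ccc(Cn2cnc3nc(Cl)nc(Cl)c32)cc1` gives 3460 nM, and compound 3 `ClCc1cccc(Cn2cnc3nc(Cl)nc(Cl)c32)c1` gives 260 nM. Compound 1 thus stands second highest of the three numbers, within the scatter of compound 2 yet far above compound 3. Compound 4 `Nc1nc(Cl)c2ncn(Cc3ccccc3CCl)c2n1` alters the core instead: amino in place of chloro on an aromatic carbon. For the measured compounds named here, no measured pair shows such a swap, so the expected step is a 1.2-fold higher number from compound 1 to compound 4 (0.07 log units; within the scatter), meaning no change beyond the scatter in either direction. Compound 4 is therefore estimated at 3500 nM, somewhere between 1200 nM and 11000 nM.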

Compound 4, concentration for total growth inhibition: 32400 nM
The estimate for compound 4 lay 9.3-fold (0.97 log units) below the measured number; measured number outside the range, above it.
By their numbers in this assay, from the lowest: compound 3; then compounds 1 and 2 (each within the scatter of the next); then compound 4.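

In this assay amino in place of chloro on this aromatic carbon, between two ring nitrogen atoms, gives an 11-fold higher number from compound 1 to compound 4 (1.04 log units; beyond the scatter) and so a weaker inhibitor of growth. For the compounds shown here, the earlier compounds varied only the chloromethyl group on the benzyl ring, so only this pair shows that the substituent on this core carbon matters too. Nothing shown here explains the loss.

Going by these compounds, whether a methoxy group or a dimethylamino group on this carbon would behave like amino or like chloro stays open. So does whether the same swap would weaken compound 3 to a similar degree.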